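A Trifluoromethyl Added to a Weak Amidine

The source may hold more compounds than are shown below. What is called first, only, known or untested is meant among the compounds shown, and "the series" means these compounds.

Compound 1, `N=C(Nc1cccc(C(F)(F)F)c1)c1cc2c(-c3ccccc3)n[nH]c2cn1`: in a functional assay on MDA-MB-231 cells (Homo sapiens) for cytotoxicity, read by MTT assay, with a stated time of 72 h (on this read-out lower numbers stand for stronger inhibition and higher numbers for weaker inhibition), compound 1 gives 22300 nM.
Compound 2, `CN1CCN(c2ccc(NC(=N)c3cc4cn[nH]c4cn3)cc2)CC1`: compound 2 gives 47500 nM.
Compound 3, `N=C(Nc1ccccc1)c1cc2cn[nH]c2cn1`: compound 3 gives > 50000 nM, which is a limit of the assay and not a number.

Compound 3 thus stands at the weak end of the three measured compounds, where (the limit of > 50000 nM in this assay, at which 1 of the 3 values shown sits). Compound 4, `N=C(Nc1cccc(C(F)(F)F)c1)c1cc2cn[nH]c2cn1`, differs from it by trifluoromethyl in place of hydrogen on an aromatic carbon. Among the measured compounds shown here, no measured step follows this change alone; the only comparable step, an at least 1.0-fold higher number from compound 2 to compound 3 (0.02 log units; that floor lies within the scatter), lies within the scatter, and compound 1 carries the same trifluoromethyl but differs elsewhere too. The expected step of a number no higher from compound 3 to compound 4 (the limit leaves the size open) is therefore small, with no direction beyond the scatter. Compound 4 is estimated at 50000 nM, within 20000 nM to 150000 nM.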

Compound 4, half-maximal inhibitory concentration: > 50000 nM
Compound 4: a limit, no number; the forecaster's own chance of this, stated with the estimate: 60%; the middle value sits exactly at the limit.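

Trifluoromethyl in place of hydrogen on an aromatic carbon gives a step that cannot be read, because compound 3 and compound 4 both stand at a limit of the assay and not at a number: the limit of > 50000 nM in this assay, at which 2 of the 4 values shown sit. The readable change is the other one: in this assay, with trifluoromethyl kept, hydrogen in place of phenyl on an aromatic carbon gives an at least 2.2-fold higher number from compound 1 to compound 4 (0.35 log units; beyond the scatter). This ties the measurable value of compound 1 to the presence of phenyl in this pair.

The compounds shown leave open whether phenyl gives a number without trifluoromethyl present. They also leave open what a methyl group or an amine on that carbon would give in this assay.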